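The compounds below may be only part of what the source reports. "The series", "measured", "known", "first", "only" and "open" are said of these compounds alone.

Compounds measured so far in a functional assay on PC-3 cells (Homo sapiens) for inhibition, read by sulforhodamine B assay, with a stated time of 48 h; a lower number here means a stronger inhibitor of growth, a higher number a weaker inhibitor of growth:

Compound 1, `Nc1cc(N)c2nc(-c3ccccc3)c(Oc3ccc(Cl)c(Cl)c3)nc2c1`, gives 3020 nM.
Compound 2, `Nc1cc(N)c2nc(-c3ccccc3)c(NCc3ccc(F)cc3)nc2c1`, gives 3470 nM.

For the measured compounds named here, compound 2 and compound 1 give numbers that lie within the scatter of each other; the step between them, a 1.1-fold higher number from compound 1 to compound 2 (0.06 log units; within the scatter), is the only measured step in this set, and it changes the same position on the shared core that is changed again in compound 3.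

Compound 3, `COc1ccc(Sc2nc3cc(N)cc(N)c3nc2-c2ccccc2)cc1`, is not yet measured. It differs from compound 2 by (4-methoxyphenyl)sulfanyl in place of (4-fluorobenzyl)amino on an aromatic carbon. Going by the values given here, the one step that bears on this change, a 1.1-fold higher number from compound 1 to compound 2 (0.06 log units; within the scatter), replaced the group on that carbon with a different group and stayed within the scatter. No step beyond the scatter has been seen at this position, so for compound 3 the expectation in this assay is no change beyond the scatter, in either direction.

The expected step for compound 3 is therefore a 1.1-fold lower number from compound 2 to compound 3 (0.02 log units; within the scatter). Compound 3 is estimated at 3300 nM, with a range from 1500 nM to 7500 nM.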

Compound 3, concentration for 50% growth inhibition: 1740 nM
For compound 3 the middle estimate is 1.9-fold (0.28 log units) above the measured one; measured number inside the range.
By their numbers in this assay, from the lowest: compounds 3, 1 and 2 (each within the scatter of the next).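

In this assay, a third group on this aromatic carbon adds two further steps, a 2.0-fold lower number from compound 2 to compound 3 (0.30 log units; within the scatter) and a 1.7-fold lower number from compound 1 to compound 3 (0.24 log units; within the scatter), so neither replacement of the earlier groups by (4-methoxyphenyl)sulfanyl leaves the scatter. This change also goes from a group with 1 hydrogen-bond donor, (4-fluorobenzyl)amino, to one with 0 hydrogen-bond donors, and it swaps the nitrogen for sulfur and adds oxygen at the same count of heavy atoms, yet compound 3, compound 2 and compound 1 remain within the scatter of one another at this position, a tolerance that holds for these three groups only. No measurement is available here that would explain this result.

All three groups carry a six-membered aromatic ring of carbon, so the compounds shown leave open whether a group lacking that ring, such as a morpholine, a short alkylamine or a carboxylic acid, would also stay within the scatter. They also leave open whether the same tolerance would hold if the phenyl group on the neighbouring carbon or the two amino groups of the shared core were replaced.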